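The source may hold more compounds than are shown below. What is called first, only, known or untested is meant among the compounds shown, and "the series" means these compounds.

Compound 1 `CCC(=O)N(c1cccc(OC)c1)C1CCCC1N(C)C`: 0.8 mg/kg
Compound 2 `CCC(=O)N(c1cccc(F)c1)C1CCCC1N(C)C`: 0.4 mg/kg
Compound 3 `CCC(=O)N(c1cc(Cl)c(Cl)c(Cl)c1)C1CCCC1N(C)C`: 4 mg/kg

These values come from a functional assay on the whole organism for positive allosteric modulation, with Mus musculus as the target (on this read-out lower numbers stand for an effect already at smaller amounts and higher numbers for an effect only at larger amounts of compound), and the three compounds share one core. Compound 2 lies within the scatter of compound 1 and well under compound 3. Compound 4 `CCC(=O)N(c1cccc(Br)c1)C1CCCC1N(C)C` has not been measured and carries bromo in place of fluoro on an aromatic carbon as its change from compound 2. Within the data shown here, the one measured step at this carbon, a 2.0-fold lower number from compound 1 to compound 2 (0.30 log units; within the scatter) for fluoro in place of methoxy, stayed within the scatter. Compound 3 (4 mg/kg) differs in more than one place, so it offers only a loose hint toward a higher number. The expected step is a 1.5-fold higher number from compound 2 to compound 4 (0.18 log units; within the scatter) and stays within the scatter of this assay as estimated here. The estimate for compound 4 is 0.6 mg/kg with an expected range from 0.2 mg/kg to 2 mg/kg on this read-out.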

Compound 4, dose for half-maximal effect: 0.1 mg/kg
For compound 4 the middle estimate is 6.0-fold (0.78 log units) above the measured one; the whole stated range lies above it.
By their numbers in this assay, from the lowest: compound 4; then compounds 2 and 1 (each within the scatter of the next); then compound 3.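

At this carbon, meta to a large group, the choice of substituent now shows a clear effect in this assay: bromo in place of fluoro gives a 4.0-fold lower number from compound 2 to compound 4 (0.60 log units; beyond the scatter), whereas the earlier step here stayed within the scatter. Bromo in place of methoxy gives an 8.0-fold lower number from compound 1 to compound 4 (0.90 log units; beyond the scatter), so compound 4 lies beyond the scatter of both compounds that differ from it only at this carbon. Nothing shown accounts for this difference.

Where iodo or chloro alone at this carbon would fall remains open. So does how an amine or a carboxylic acid there would read in this assay.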